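The compounds below may be only part of what the source reports. "The series", "measured", "known", "first", "only" and "open" are said of these compounds alone.

Series notes. Compound 2 `COC(=O)Cn1cc(CNC(=O)c2cnc(Nc3ccc(C#N)cc3)cc2Oc2c(C)cc(C)cc2C)nn1` gives in an ADME assay on MT4 cells (Homo sapiens) for cytotoxicity, read by MTT assay, with a stated time of 5 days (a lower number here means that less compound is tolerated, a higher number that more compound is tolerated), a value of 13800 nM, the lowest of the two numbers in hand. Its nearest neighbour is compound 1 `Cc1cc(C)c(Oc2cc(Nc3ccc(C#N)cc3)ncc2C(=O)NCc2cn(Cc3cccc(Cl)c3)nn2)c(C)c1`, which in this assay gives 187000 nM. Within the data shown here, the single step measured so far, a 14-fold lower number from compound 1 to compound 2 (1.13 log units; beyond the scatter), goes with the change of 3-chlorophenyl to methoxycarbonyl on a saturated chain carbon bound to an aromatic nitrogen, and it lies beyond the scatter.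

Compound 3 `Cc1cc(C)c(Oc2cc(Nc3ccc(C#N)cc3)ncc2C(=O)NCc2cn(Cc3ccc(F)cc3)nn2)c(C)c1` is not yet measured in this assay. It differs from compound 2 as follows: 4-fluorophenyl in place of methoxycarbonyl on a saturated chain carbon bound to an aromatic nitrogen. Among the measured compounds shown here, this is close to the reverse of the one measured step: the methoxycarbonyl leaves and an aryl group returns at the same place. The step from compound 1 to compound 2 therefore bears directly on it, and a step of similar size in the opposite direction, towards a higher number, is expected. Compound 3 is expected to show about 120000 nM in this assay, with a range from 40000 nM to 300000 nM. The expected step is an 8.7-fold higher number from compound 2 to compound 3 (0.94 log units; beyond the scatter). For the measured compounds named here, only one step supports this, and the halogen on the phenyl differs from that of compound 1, so the range is kept wide.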

Compound 3, half-maximal cytotoxic concentration: >= 153000 nM
Compound 3: a limit, no number (the forecaster's own chance of this, stated with the estimate: 15%); middle value at least 1.2-fold (0.10 log units) away from the limit.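

In this assay compound 3 stands as a limit of the assay and not as a number: the limit of >= 153000 nM in this assay, at which 1 of the 3 values shown sits. The series now holds an at least 11-fold higher number from compound 2 to compound 3 (1.04 log units; beyond the scatter), which gives a second comparison at this place, on a saturated chain carbon bound to an aromatic nitrogen, so the low number of compound 2 no longer rests on compound 1 alone. Of the three groups shown, methoxycarbonyl alone goes with the low number, and 3-chlorophenyl in compound 1 and 4-fluorophenyl in compound 3 both go with far higher numbers, although the step between these two cannot be read and the two halogenated phenyl groups cannot be placed in order.

The compounds shown do not separate the methoxycarbonyl group itself from the mere absence of an aromatic ring at this place, and a carboxylic acid, a primary amide or a small alkyl chain there would bear on that question. Going by these compounds, it also stays open whether an amine or a longer chain ending in methoxycarbonyl would go with a number as low as that of compound 2.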